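The source may report more compounds than this note shows. Statements on the series, on what has been measured and on what is new or still open speak of the compounds shown alone.

Within the data shown here, in a functional assay on CCRF-CEM cells (Homo sapiens) (on this read-out lower numbers stand for stronger inhibition and higher numbers for weaker inhibition), compound 1 `COC(=O)c1nn([C@@H]2O[C@H](CO)[C@@H](O)[C@H]2O)cc1I` gives 1500 nM, the lower of the two numbers so far, while compound 2 `CCCCOC(=O)c1nn([C@@H]2O[C@H](CO)[C@@H](O)[C@H]2O)cc1I` gives 19000 nM. Compound 3 `Cc1noc(-c2nn([C@@H]3O[C@H](CO)[C@@H](O)[C@H]3O)cc2I)n1` is still unmeasured. It differs from compound 1 as follows: 3-methyl-1,2,4-oxadiazol-5-yl in place of methoxycarbonyl on an aromatic carbon. Among the measured compounds shown here, the only measured step, a 13-fold higher number from compound 1 to compound 2 (1.10 log units; beyond the scatter), adds propyl to that same methoxycarbonyl group and is large, but it brings in no new ring, so it is only a loose guide. A moderate rise in this assay, smaller than that step, is therefore expected. The expected change is a 2.7-fold higher number from compound 1 to compound 3 (0.43 log units; beyond the scatter). For compound 3 the estimated value is 4000 nM, within a range of 800 nM to 20000 nM.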

Compound 3, half-maximal inhibitory concentration: 2600 nM
The estimate for compound 3 lay 1.5-fold (0.19 log units) above the measured number, and the stated range covers the measured number.
By their numbers in this assay, from the lowest: compounds 1 and 3 (each within the scatter of the next); then compound 2.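

In this assay, 3-methyl-1,2,4-oxadiazol-5-yl can replace methoxycarbonyl on this aromatic carbon with a 1.7-fold higher number from compound 1 to compound 3 (0.24 log units; within the scatter), so an aromatic ring can stand here without a clear change in the read-out. Against butoxycarbonyl, the same ring gives a 7.3-fold lower number from compound 2 to compound 3 (0.86 log units; beyond the scatter), which shows that, among these compounds, a group with more heavy atoms than methoxycarbonyl need not bring the rise seen with compound 2. No measured evidence explains these steps.

Still open, on these data alone, is whether other five-membered aromatic rings behave in the same way, and how a carboxylic acid or an amide would fare at this position.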